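From 4-cyanobenzyl to 3-fluorobenzyl: a small expected step

The compounds below may be only part of what the source reports. "The series", "measured", "known", "first", "only" and "open" are said of these compounds alone.

In a functional assay on A-375 cells (Homo sapiens) for antiproliferative activity, read by MTT assay, with a stated time of 24 h (on this read-out lower numbers stand for stronger inhibition and higher numbers for weaker inhibition), compound 1 `C#CCOc1ccc2c(=O)c(-c3cc(OC)c(OC)cc3OC)coc2c1` gives 3680 nM, compound 2 `COc1cc(OC)c(-c2coc3cc(OCc4ccccc4F)ccc3c2=O)cc1OC` gives 2100 nM and compound 3 `COc1cc(OC)c(-c2coc3cc(OCc4ccc(C#N)cc4)ccc3c2=O)cc1OC` gives 1550 nM. Two steps place compound 3: a 1.4-fold lower number from compound 2 to compound 3 (0.13 log units; within the scatter) sits within the scatter, while a 2.4-fold lower number from compound 1 to compound 3 (0.38 log units; beyond the scatter) goes beyond it, though only modestly.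

Compound 4 `COc1cc(OC)c(-c2coc3cc(OCc4cccc(F)c4)ccc3c2=O)cc1OC` alters one group: 3-fluorophenyl in place of 4-cyanophenyl on a saturated chain carbon bound to an oxygen on an aromatic ring. Here 3-fluorophenyl takes the place of 4-cyanophenyl on a saturated chain carbon bound to an oxygen on an aromatic ring. For the measured compounds named here, no measured compound carries 3-fluorophenyl. The nearest guide is compound 2, which carries 2-fluorophenyl, and its exchange for 4-cyanophenyl gave only a 1.4-fold lower number from compound 2 to compound 3 (0.13 log units; within the scatter). The step of a 1.8-fold lower number from compound 1 to compound 2 (0.24 log units; within the scatter) also stayed within the scatter. In this assay, a slightly higher number is therefore expected, with no step beyond the scatter, and the estimate is a 1.3-fold higher number from compound 3 to compound 4 (0.11 log units; within the scatter). For compound 4 the estimated value is 2000 nM, with an expected range of 1000 nM to 4000 nM.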

Compound 4, half-maximal inhibitory concentration: 1300 nM
For compound 4 the middle estimate is 1.5-fold (0.19 log units) above the measured one; low and high end bracket the measured number.
By their numbers in this assay, from the lowest: compounds 4, 3, 2 and 1 (each within the scatter of the next, the first and the last beyond it).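

Compound 4 gives this position its first direct test of one atom in two places on the benzyl ring, 2-fluorophenyl against 3-fluorophenyl, and in this assay the result, a 1.6-fold lower number from compound 2 to compound 4 (0.21 log units; within the scatter), stays within the scatter, as does the exchange of a nitrile-bearing ring for a fluorine-bearing one, a 1.2-fold lower number from compound 3 to compound 4 (0.08 log units; within the scatter). Only the comparison with the ethynyl compound clears the scatter, a 2.8-fold lower number from compound 1 to compound 4 (0.45 log units; beyond the scatter), and even that is modest; compound 3 shows the same, while compound 2 goes against this pattern, as its step from compound 1 stays within the scatter. Nothing available explains why these aromatic groups give such similar numbers.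

Still open, on these data alone, is whether an amine or a carboxylic acid on this phenyl ring would move the number beyond the scatter. As far as these compounds go, a longer chain between the oxygen and the ring remains an equally open question.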